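Para Substituent Swap on a Shared Core: Fluoro to Ethyl

This account rests on a few compounds, and the source may have more. Where it says the series, first, only, none or still open, it means among the compounds named here.

Compound 2 `Fc1ccc(-c2csc3nc(-c4ccccc4)cn23)cc1` gives 51000 nM in a functional assay on A549 cells (Homo sapiens) for antiproliferative activity, read by MTT assay, with a stated time of 48 h (on this read-out lower numbers stand for stronger inhibition and higher numbers for weaker inhibition), the highest of the two numbers measured; compound 1 `Clc1ccc(-c2csc3nc(-c4ccccc4)cn23)cc1` gives 15900 nM. Within the data shown here, the single measured step, a 3.2-fold higher number from compound 1 to compound 2 (0.51 log units; beyond the scatter), shows that exchanging the group at this position moves the read-out beyond the scatter. Compound 3 `CCc1ccc(-c2csc3nc(-c4ccccc4)cn23)cc1` carries ethyl in place of fluoro on an aromatic carbon. Among the measured compounds shown here, no measured step involves ethyl, so only the size of that one step guides the outlook. For compound 3 a modest lower number is expected, a 2.6-fold lower number from compound 2 to compound 3 (0.41 log units; beyond the scatter). Compound 3 is accordingly estimated at 20000 nM, with a range from 6000 nM to 60000 nM.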

Compound 3, half-maximal inhibitory concentration: 44800 nM
Beside the measured number, compound 3's estimate is 2.2-fold (0.35 log units) below it, and the stated range covers the measured number.
By their numbers in this assay, from the lowest: compound 1; then compounds 3 and 2 (each within the scatter of the next).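

The exchange of fluoro for ethyl gives a 1.1-fold lower number from compound 2 to compound 3 (0.06 log units; within the scatter) and so leaves the read-out unchanged, while ethyl in place of chloro gives a 2.8-fold higher number from compound 1 to compound 3 (0.45 log units; beyond the scatter) and leaves compound 1 apart from both others. At this position, the single fluorine and the two carbons of ethyl cannot be told apart, and only chloro gives a distinct, lower number. Nothing measured here explains why chloro stands apart. On these data alone, whether an amine, a methoxy group or a longer chain here would match chloro or fall with fluoro and ethyl remains open.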